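A few compounds are considered here, and "the series" means these few. Any claim that something is new, unique, unknown or untested is made for them only; others in the source may bear on it.

Compound 1 `Cc1cc(C#N)cc(C)c1Sc1ccnc(Nc2ccc(C#N)cc2)n1` and compound 2 `Cc1cc(C)c(Sc2ccnc(Nc3ccc(C#N)cc3)n2)c(C)c1` share one core, while compound 3 `Cc1cc(C#N)cc(C)c1Nc1nc(Nc2ccc(C#N)cc2)ncc1Cl` and compound 4 `Cc1cc(C)c(Nc2nc(Nc3ccc(C#N)cc3)ncc2Cl)c(C)c1` share another; the difference between the two cores is not broken down here. In a physicochemical assay for lipophilicity (on this read-out lower numbers stand for lower lipophilicity and higher numbers for higher lipophilicity), compound 1 gives 2.06, compound 2 gives 2.16, and compound 3 gives 1.11. Compound 3 therefore stands lowest of the three measured numbers, clearly apart from both compound 1 and compound 2.

The change from compound 1 to compound 2 is methyl in place of cyano on an aromatic carbon. In this assay it made a number 0.10 log units higher from compound 1 to compound 2 (within the scatter), a step that does not rise above the usual scatter of such measurements.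

Compound 4 is not yet measured in this assay. Within the data shown here, it differs from compound 3 by methyl in place of cyano on an aromatic carbon, which is the same change, at the same kind of place, as the one that separates compound 1 from compound 2. Because a number 0.10 log units higher from compound 1 to compound 2 (within the scatter) was small, a step of comparable size is expected from compound 3 to compound 4, namely a number 0.10 log units higher from compound 3 to compound 4 (within the scatter). This expectation rests on a single measured pair and on the assumption that the change behaves alike on the two cores, which the data cannot confirm. In this assay compound 4 is therefore estimated to give 1.21, most likely between 0.85 and 1.55.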

Compound 4, partition coefficient: 1.72
The estimate for compound 4 lay 0.51 log units below the measured number; measured number outside the range, above it.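

In this assay, methyl in place of cyano on an aromatic carbon gave a number 0.61 log units higher from compound 3 to compound 4 (beyond the scatter), while the same change on the core of compound 1 gave a number 0.10 log units higher from compound 1 to compound 2 (within the scatter). The small step seen on the one core therefore did not carry over in size to the other, and a step measured on one of these cores proved a poor guide to the size of the step on the other. Among these compounds, with only two pairs, this does not show how the change would behave on any further core or which part of the two cores goes with the difference in size, and nothing available here accounts for that difference.

The compounds shown carry only cyano or methyl on this aromatic carbon, so it stays open how an amine, a carboxylic acid or a longer chain at the same place would read on either core, and whether such groups would also give steps of unequal size on the two cores. The two cores also differ from each other in more than one place, which leaves open which of those differences matters for the size of the step.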